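This account rests on a few compounds, and the source may have more. Where it says the series, first, only, none or still open, it means among the compounds named here.

Values so far in a physicochemical assay for lipophilicity, using the shake flask method, in phosphate buffer, measured as octanol-water partition, with a stated time of 30 min, at pH 7.4; a lower number here means a more polar compound, a higher number a more lipophilic compound:
- compound 1 `C[C@@H]1CC(=O)N(c2cnc(NCc3c(F)ccc4c3CCO4)n3cnnc23)C1`: 1.8
- compound 2 `CN(c1ccn(C)n1)c1cnc(NCc2c(F)ccc3c2CCO3)n2cnnc12`: 1.8

Against compound 1, compound 2 stands level at 1.8. The next entry is compound 3 `CN(C(=O)c1ccccc1)c1cnc(NCc2c(F)ccc3c2CCO3)n2cnnc12`, and the change from compound 2 is benzoyl in place of 1-methyl-1H-pyrazol-3-yl on a nitrogen on an aromatic ring. Cut one bond further out, this reads methyl(1-methyl-1H-pyrazol-3-yl)amino to benzoyl(methyl)amino.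

Going by the values given here, only one measured step bears on this, and only loosely: no change at the digits printed from compound 1 to compound 2 (within the scatter). That step put methyl(1-methyl-1H-pyrazol-3-yl)amino in place of 4-methyl-2-oxopyrrolidin-1-yl on an aromatic carbon. Among the compounds with values here, no measured step covers benzoyl at this nitrogen. Within the data shown here, with no change at the digits printed from compound 1 to compound 2 (within the scatter) as the only guide, no large shift is carried over from the data. The upward direction expected here rests on the structural change alone, with a six-membered aromatic ring of carbon only entering for a five-membered aromatic ring with 2 hetero atoms. The expected move in this assay is a number 0.40 log units higher from compound 2 to compound 3 (beyond the scatter), a modest one. For compound 3 the estimate is 2.2, with an expected range of 1.7 to 2.7.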

Compound 3, distribution coefficient: 2.4
Compound 3: the middle estimate sits 0.20 log units below what was measured, and the stated range covers the measured number.
By their numbers in this assay, from the lowest: compounds 1 and 2 (each within the scatter of the next); then compound 3.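

In this assay, going by these compounds alone, a nitrogen on an aromatic ring now proves to be a place where the group carried can move the read-out: benzoyl in place of 1-methyl-1H-pyrazol-3-yl gives a number 0.60 log units higher from compound 2 to compound 3 (beyond the scatter), whereas the only step available before it gave no change at the digits printed from compound 1 to compound 2 (within the scatter). Benzoyl(methyl)amino in place of 4-methyl-2-oxopyrrolidin-1-yl on an aromatic carbon gives a number 0.60 log units higher from compound 1 to compound 3 (beyond the scatter), so compound 3 is the first compound in this set to stand apart from the others beyond the scatter, and by a step of the same printed size from each. Nothing measured here accounts for this move.

The benzoyl change brings in a six-membered aromatic ring of carbon only and a double bond outside aromatic rings in one step, and the compounds shown do not separate the two. A plain phenyl on the same kind of nitrogen would divide that step, and a carboxylic acid or a dimethylamino group on the benzoyl ring would test how far the value in this assay follows the group carried there.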